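Anilinoquinazoline sulfonamides: methyl position on the aniline ring

The compounds below may be only part of what the source reports. "The series", "measured", "known", "first", "only" and "open" are said of these compounds alone.

Measured compounds in a functional assay on A549 cells (Homo sapiens) for antiproliferative activity, read by MTT assay, with a stated time of 72 h; on this read-out higher numbers stand for weaker inhibition and lower numbers for stronger inhibition:
compound 1, `COc1cc2ncnc(Nc3cccc(C)c3)c2cc1OCCCCC(=O)Nc1ccc(S(N)(=O)=O)cc1`, 16000 nM
compound 2, `COc1cc2ncnc(Nc3ccc(C)cc3)c2cc1OCCCCC(=O)Nc1ccc(S(N)(=O)=O)cc1`, > 40000 nM (a limit of the assay)
compound 3, `Cc1cccc(Nc2ncnc3ccc(NC(=S)Nc4ccc(S(N)(=O)=O)cc4)cc23)c1`, > 40000 nM (a limit of the assay)

Among the compounds with values here, compound 1 is the one compound with a measured number in this assay. Compound 2 gives only a limit of the assay in this assay. Compound 3 likewise gives only a limit of the assay. Two of the three values sit at that limit, as noted in the limit of > 40000 nM in this assay, at which 2 of the 3 values shown sit.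

Compound 1 and compound 2 share one core and differ by 4-methylphenyl in place of 3-methylphenyl on a nitrogen on an aromatic ring. The step of an at least 2.5-fold higher number from compound 1 to compound 2 (0.39 log units; beyond the scatter) goes toward weaker inhibition and is beyond the scatter, though its full size is hidden by the limit.

Compound 3 carries a different core from compound 1; the difference between the two cores is not broken down here. Compound 4, `Cc1ccc(Nc2ncnc3ccc(NC(=S)Nc4ccc(S(N)(=O)=O)cc4)cc23)cc1`, is not yet measured. It differs from compound 3 by 4-methylphenyl in place of 3-methylphenyl on a nitrogen on an aromatic ring, the same change as from compound 1 to compound 2, at the same kind of place.

Compound 4 is expected to sit at or past the limit of the assay, with the expected step that the limit leaves unreadable from compound 3 to compound 4, because compound 3 already gives > 40000 nM and the same change from compound 1 to compound 2 gave an at least 2.5-fold higher number from compound 1 to compound 2 (0.39 log units; beyond the scatter). For compound 4 the estimated value is 70000 nM, expected to lie between 35000 nM and 200000 nM.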

Compound 4, half-maximal inhibitory concentration: 2840 nM
Estimate against measurement, compound 4: 25-fold (1.39 log units) above; the whole stated range lies above it.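

In this assay, putting 4-methylphenyl in place of 3-methylphenyl on the thiourea-linked core gives an at least 14-fold lower number from compound 3 to compound 4 (1.14 log units; beyond the scatter), toward stronger inhibition. Set beside the earlier step, which went toward weaker inhibition, this shows that the change does not carry from one core to the other with the same direction or size: the same change on two cores in this assay, an at least 2.5-fold higher number (0.39 log units; beyond the scatter) from compound 1 to compound 2 and an at least 14-fold lower number (1.14 log units; beyond the scatter) from compound 3 to compound 4, at least 35-fold (1.54 log units) apart, beyond the scatter of two such steps

What this does not show is the true size of either step or of the gap between them, or which part of the core governs the outcome, since only two pairs are available, the difference between the cores is not broken down, and each step rests on a limit rather than on two numbers: the limit of > 40000 nM in this assay, at which 2 of the 4 values shown sit.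

The compounds shown leave open which feature of the core decides the direction of the step; a urea linker in place of the thiourea on the core of compound 3, or a methoxy group added to that core, would begin to separate these features. Also open, from the compounds shown here alone, is whether the same reversal would appear with a group other than methyl on the aniline ring, such as chloro or methoxy.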